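The source may hold more compounds than are shown below. What is called first, only, known or untested is meant among the compounds shown, and "the series" means these compounds.

Working notes on the series in an ADME assay on microsomes from liver (Mus musculus) for metabolic stability, read by LC-MS, with a stated time of 10 min; on this read-out lower numbers stand for a less stable compound and higher numbers for a more stable compound. Compound 1 `C[C@@H]1CN(c2cccc3c2C[C@H](CN(C)[C@H]2CCCc4cccnc42)NC3)C[C@H](C)N1` gives 85.6% in this assay. Compound 2 `CN1CCN(c2cccc3c2C[C@H](CN(C)[C@H]2CCCc4cccnc42)NC3)CC1` gives 17% in this assay, the lowest of the three measured compounds. The two cores differ by 4-methylpiperazin-1-yl in place of 3,5-dimethylpiperazin-1-yl on an aromatic carbon, and the step is a number 68.6 percentage points lower from compound 1 to compound 2 (beyond the scatter). Compound 3 `C[C@@H]1CN(c2cccc3c2C[C@H](CN(C)[C@H]2CCCc4cccnc42)NC3)C[C@H](C)N1C` gives 39.6% in this assay. It arises from compound 1 by methyl in place of hydrogen on an amine nitrogen in a ring, and the step is a number 46 percentage points lower from compound 1 to compound 3 (beyond the scatter). The remaining step is a number 22.6 percentage points higher from compound 2 to compound 3 (beyond the scatter).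

Compound 4 `CN1CCN(c2cccc3c2C[C@H](CN(C)[C@H]2CCCc4cccnc42)N(C)C3)CC1` is not yet measured. It arises from compound 2 by methyl in place of hydrogen on an amine nitrogen in a ring. This is the same kind of change as that from compound 1 to compound 3, but not the same: there the methyl enters on an amine nitrogen in a ring of a six-membered non-aromatic ring with 2 nitrogen, next to two ring atoms that each bear a methyl group, three ring bonds from the ring atom that bears a large group; here it enters on an amine nitrogen in a ring of a six-membered non-aromatic ring with 1 nitrogen, part of a fused or bridged system of two rings, next to the ring atom that bears a large group. For the measured compounds named here, only one measured instance of the change exists, at a different place, so the direction is uncertain. The expected step is a number 7 percentage points lower from compound 2 to compound 4 (within the scatter), smaller than a number 46 percentage points lower from compound 1 to compound 3 (beyond the scatter) because compound 2 already stands at 17% and the read-out has little room to fall further. Compound 4 is therefore estimated at 10%, with a range from 3% to 25%.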

Compound 4, percent of the compound remaining: 41.7%
Compound 4: middle estimate off by 31.7 percentage points, on the low side, and the stated range ends below it.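

In this assay, methyl in place of hydrogen on an amine nitrogen in a ring gives a number 24.7 percentage points higher from compound 2 to compound 4 (beyond the scatter), and set beside the earlier instance, the change does not carry over from one core to the other with a single direction: the same change on two cores in this assay, a number 46 percentage points lower (beyond the scatter) from compound 1 to compound 3 and a number 24.7 percentage points higher (beyond the scatter) from compound 2 to compound 4, 70.7 percentage points apart, beyond the scatter of two such steps

The two instances differ in more than the core, since in compound 3 the methyl enters on the amine nitrogen of a six-membered non-aromatic ring with 2 nitrogen, while in compound 4 it enters on the amine nitrogen of a six-membered non-aromatic ring with 1 nitrogen, part of a fused or bridged system of two rings. The pair therefore shows that the outcome of this change cannot be transferred between these two places and cores, but it does not separate the effect of the place from that of the surrounding core, and with one instance at each place it gives no rule for either.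

The compounds shown leave open how the same methyl on the fused-system nitrogen behaves when the aromatic carbon carries 3,5-dimethylpiperazin-1-yl, as in compound 1, which would test the place on a second core. Also open, from the compounds shown here alone, is whether an ethyl or an acetyl group on that nitrogen would follow the step seen with methyl.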